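Thiophene carboxamide series: moving the methyl on the benzamide ring

This account rests on a few compounds, and the source may have more. Where it says the series, first, only, none or still open, it means among the compounds named here.

Measured so far:
compound 1, `Cc1ccc(C(=O)Nc2sc3c(c2C(N)=O)CCN(Cc2ccc(Cl)cc2Cl)C3)cc1` — > 50000 nM
compound 2, `NC(=O)c1c(NC(=O)c2ccccc2F)sc2c1CCN(C(=S)Nc1ccccc1Cl)C2` — 19400 nM
compound 3, `Cc1ccccc1C(=O)Nc1sc2c(c1C(N)=O)CCN(C(=S)Nc1ccccc1Cl)C2` — 35300 nM

The read-out is a functional assay on HeLa cells (Homo sapiens) for antiproliferative activity, with a stated time of 24 h; a higher number here means a weaker inhibitor, a lower number a stronger inhibitor. Compound 1 gives only a limit of the assay in this assay, > 50000 nM, and no number. Compound 2 gives 19400 nM in this assay. Compound 3 gives 35300 nM in this assay, the highest of the two numbers; its nearest neighbour is compound 2, and the step of a 1.8-fold higher number from compound 2 to compound 3 (0.26 log units; within the scatter) is within the scatter. One further value, that of compound 1, is a limit (the limit of > 50000 nM in this assay, at which 1 of the 3 values shown sits).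

Compound 4, `Cc1ccc(C(=O)Nc2sc3c(c2C(N)=O)CCN(C(=S)Nc2ccccc2Cl)C3)cc1`, is not yet measured. It differs from compound 3 in one place: 4-methylphenyl in place of 2-methylphenyl on a carbonyl carbon. Among the compounds with values here, no measured step bears directly on this change. Within the data shown here, the only measured step, a 1.8-fold higher number from compound 2 to compound 3 (0.26 log units; within the scatter), concerns a different change on the same ring and is within the scatter. Compound 1 also carries the 4-methylphenyl group but differs from compound 4 elsewhere as well, so its limit cannot be read as a step.

With no step beyond the scatter on this ring, compound 4 is expected to sit near compound 3, the estimated step being a 1.1-fold higher number from compound 3 to compound 4 (0.05 log units; within the scatter). The estimate for compound 4 in this assay is 40000 nM, with a range from 15000 nM to 120000 nM.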

Compound 4, half-maximal inhibitory concentration: 26300 nM
Compound 4: middle estimate off by 1.5-fold (0.18 log units), on the high side; measured number inside the range.
By their numbers in this assay, from the lowest: compounds 2, 4 and 3 (each within the scatter of the next). At a limit, above all of these: compound 1.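

In this assay, moving the methyl from the 2-methylphenyl to the 4-methylphenyl arrangement on the carbonyl carbon gives a 1.3-fold lower number from compound 3 to compound 4 (0.13 log units; within the scatter), so this change, with the same atoms joined differently and the rest of the structure held constant, has no effect that this read-out can resolve. Comparison with the fluoro analogue gives a 1.4-fold higher number from compound 2 to compound 4 (0.13 log units; within the scatter), which means that 2-fluorophenyl, 2-methylphenyl and 4-methylphenyl cannot be ranked in this set, as all three steps among compounds 2, 3 and 4 lie within the scatter. With 4-methylphenyl kept on the carbonyl carbon, replacing the group on the amine nitrogen in a ring gives an at least 1.9-fold lower number from compound 1 to compound 4 (0.27 log units; that floor lies within the scatter), so this first direct comparison at that nitrogen does not establish a real difference, since its floor also lies within the scatter.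

Going by these compounds, the true size of that last step stays open, as compound 1 gives a limit of the assay and no number: the limit of > 50000 nM in this assay, at which 1 of the 4 values shown sits. On these data alone, it also remains open whether a methoxy group, an amine or a carboxylic acid on the benzamide ring would shift the number beyond the scatter, or whether this ring tolerates such groups as evenly as it does methyl and fluoro.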